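Hydroxy to Nitro: Expected Cytotoxicity of Compound 4

The source may report more compounds than this note shows. Statements on the series, on what has been measured and on what is new or still open speak of the compounds shown alone.

Three measured compounds share one core. In an ADME assay on Huh-7 cells (Homo sapiens) for cytotoxicity (on this read-out higher numbers stand for lower toxicity in this test and lower numbers for higher toxicity in this test), compound 1 `O=c1cc(CNCc2ccccc2)oc2ccc(O)c(O)c12` gives only a limit of the assay, > 100000 nM. Compound 2 `O=c1cc(CNCc2cccc(Br)c2)oc2ccc(O)c(O)c12` also gives only a limit, > 100000 nM. Compound 3 `O=c1cc(CNCc2cccc(O)c2)oc2ccc(O)c(O)c12` likewise gives only a limit, > 100000 nM. Compound 3 thus stands at the limit of > 100000 nM in this assay, at which 3 of the 3 values shown sit. The steps a step that the two limits leave unreadable from compound 1 to compound 2, a step that the two limits leave unreadable from compound 1 to compound 3 and a step that the two limits leave unreadable from compound 2 to compound 3 remain unreadable between limits. Compound 4 `O=c1cc(CNCc2cccc([N+](=O)[O-])c2)oc2ccc(O)c(O)c12` differs from compound 3 by nitro in place of hydroxy on an aromatic carbon. The measured steps give no readable direction. With compound 3 sitting at a limit, compound 4 is expected to show a step that the limit leaves unreadable from compound 3 to compound 4. The value of compound 4 is estimated at 150000 nM, between 50000 nM and 500000 nM.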

Compound 4, half-maximal cytotoxic concentration: > 100000 nM
Compound 4 gave a limit, no number; the forecaster's own chance of this, stated with the estimate: 80%; the middle value does not contradict the limit.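

No step among compound 1, compound 2, compound 3 and compound 4 can be read in this assay, as each gave only a limit: the limit of > 100000 nM in this assay, at which 4 of the 4 values shown sit.

The compounds shown leave open whether hydrogen, bromo, hydroxy or nitro at this place makes any difference in this assay.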